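Pyridin-3-yl in Place of Pyridin-4-yl in Compound 4

The compounds below may be only part of what the source reports. "The series", "measured", "known", "first", "only" and "open" are said of these compounds alone.

Measured so far:
compound 1 `Cc1nn(-c2nc(-c3ccc(Cl)c(Cl)c3)c(SC(C)C)s2)c(C(=O)O)c1-c1ccccc1`: 3000 nM
compound 2 `CC(=O)Nc1ccc(-c2c(C)nn(-c3nc(-c4ccc(Cl)c(Cl)c4)c(SC(C)C)s3)c2C(=O)O)cc1`: 139000 nM
compound 3 `Cc1nn(-c2nc(-c3ccc(Cl)c(Cl)c3)c(SC(C)C)s2)c(C(=O)O)c1-c1ccncc1`: 5900 nM

In a functional assay on BJAB cells (Homo sapiens) for antiproliferative activity, with a stated time of 4 days (on this read-out higher numbers stand for an effect only at larger amounts of compound and lower numbers for an effect already at smaller amounts), compound 3 stands second highest of the three numbers. Its nearest neighbour is compound 1, with a 2.0-fold higher number from compound 1 to compound 3 (0.29 log units; within the scatter), and its furthest is compound 2, with a 24-fold lower number from compound 2 to compound 3 (1.37 log units; beyond the scatter). Compound 4 `Cc1nn(-c2nc(-c3ccc(Cl)c(Cl)c3)c(SC(C)C)s2)c(C(=O)O)c1-c1cccnc1` differs from compound 3 by pyridin-3-yl in place of pyridin-4-yl on an aromatic carbon. Within the data shown here, the only step that bears on this position without adding atoms, a 2.0-fold higher number from compound 1 to compound 3 (0.29 log units; within the scatter), stayed within the scatter; the large step of a 46-fold higher number from compound 1 to compound 2 (1.67 log units; beyond the scatter) involved a far bigger group and does not speak to moving the ring nitrogen. Compound 4 is therefore expected to show a 1.2-fold lower number from compound 3 to compound 4 (0.07 log units; within the scatter), no change beyond the scatter, with an estimated 5000 nM ranging from 2000 nM to 13000 nM.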

Compound 4, half-maximal effective concentration: 12000 nM
The estimate for compound 4 lay 2.4-fold (0.38 log units) below the measured number, within the range that was stated.
By their numbers in this assay, from the lowest: compounds 1 and 3 (each within the scatter of the next); then compound 4; then compound 2.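

In this assay, the place of the ring nitrogen alone proved to matter at this position: with the same atoms joined differently, the change gave a 2.0-fold higher number from compound 3 to compound 4 (0.31 log units; beyond the scatter). Pyridin-3-yl in place of phenyl gave a 4.0-fold higher number from compound 1 to compound 4 (0.60 log units; beyond the scatter), a step beyond the scatter, while pyridin-3-yl in place of 4-acetamidophenyl gave a 12-fold lower number from compound 2 to compound 4 (1.06 log units; beyond the scatter). No evidence is available to explain these differences. The compounds shown leave open how pyridin-2-yl would stand at this position, and whether a phenyl ring carrying an amine would follow 4-acetamidophenyl.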